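Fluoro for methylsulfanyl on the aryl piperazine

The source may hold more compounds than are shown below. What is called first, only, known or untested is meant among the compounds shown, and "the series" means these compounds.

Compound 2 `CSc1ccccc1N1CCN(CCCCn2ncc(=O)n(C)c2=O)CC1` gives 1.8 nM in an assay for displacement of a labelled ligand from Adrenergic receptor alpha-1 (Homo sapiens); on this read-out higher numbers stand for weaker inhibition and lower numbers for stronger inhibition. Compound 1 `CCOc1ccccc1N1CCN(CCCCn2ncc(=O)n(C)c2=O)CC1` gives 1.8 nM, and the two are level at the digits shown, together the lowest pair of the three; the swap from compound 1 to compound 2 reads no change at the digits printed from compound 1 to compound 2 (within the scatter). Among the compounds with values here, compound 3 `COc1ccc(N2CCN(CCCCn3ncc(=O)n(C)c3=O)CC2)c(C#N)c1` gives 380 nM, a far higher number, but it differs from compound 2 in more than one place and no single step connects them.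

Compound 4 `Cn1c(=O)cnn(CCCCN2CCN(c3ccccc3F)CC2)c1=O` carries the change (fluoro in place of methylsulfanyl on an aromatic carbon). Within the data shown here, the one measured step that bears on this position is no change at the digits printed from compound 1 to compound 2 (within the scatter), where one group on the same aromatic carbon replaced another without moving the number. That step only shows tolerance for one exchange; the entering group here is smaller than either of those. The expected step is therefore a modest rise, a 3.3-fold higher number from compound 2 to compound 4 (0.52 log units; beyond the scatter), that may not clear the scatter. Compound 4 is estimated at 6 nM, with a range from 2 nM to 20 nM.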

Compound 4, inhibition constant: 9.73 nM
Beside the measured number, compound 4's estimate is 1.6-fold (0.21 log units) below it; the measured number falls inside the stated range.
By their numbers in this assay, from the lowest: compounds 1 and 2 (each within the scatter of the next); then compound 4; then compound 3.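

Fluoro is the first group at this aromatic carbon to move the number in this assay beyond the scatter: the step reads a 5.4-fold higher number from compound 2 to compound 4 (0.73 log units; beyond the scatter), and the step from the ethoxy analogue reads a 5.4-fold higher number from compound 1 to compound 4 (0.73 log units; beyond the scatter). Compound 1 and compound 2 alone showed only that ethoxy and methylsulfanyl read level, so the position looked tolerant; it is now seen to discriminate among groups, though the loss with fluoro is modest. Nothing in hand accounts for the rise at this position.

Three groups on this carbon cannot show whether the number follows the heavy-atom count of the group or some other feature of it. A propoxy group, an amino group or a plain hydrogen at the same place would extend the comparison.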